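Chloro for Methyl: What Compound 4 Should Show

The compounds below may be only part of what the source reports. "The series", "measured", "known", "first", "only" and "open" are said of these compounds alone.

Compound 1 `CCOC(=O)c1c(-c2c(Cl)c3ccccc3oc2=O)nn(-c2cccc(C)c2)c1C(=O)OCC` and compound 2 `CCOC(=O)c1c(-c2c(Cl)c3ccccc3oc2=O)nn(-c2cccc(Cl)c2)c1C(=O)OCC` share one core; compound 3 `CCOC(=O)c1c(-c2cc3ccc(OCC=C(C)C)cc3oc2=O)nn(-c2cccc(C)c2)c1C(=O)OCC` and the still unmeasured compound 4 `CCOC(=O)c1c(-c2cc3ccc(OCC=C(C)C)cc3oc2=O)nn(-c2cccc(Cl)c2)c1C(=O)OCC` share another, and the difference between the two cores is not broken down here. In a functional assay on HeLa cells (Homo sapiens) for cytotoxicity, read by MTT assay, with a stated time of 48 h (on this read-out higher numbers stand for weaker inhibition and lower numbers for stronger inhibition), compound 1 gives 30000 nM, and compound 2 gives 40000 nM. The change between them, (chloro in place of methyl on an aromatic carbon), made a step of a 1.3-fold higher number from compound 1 to compound 2 (0.12 log units; within the scatter). In this assay compound 3 gives 150000 nM. Compound 4 carries the same change, (chloro in place of methyl on an aromatic carbon), on the core of compound 3. Going by the values given here, the expected step of a 1.2-fold higher number from compound 3 to compound 4 (0.08 log units; within the scatter) in this assay is placed close to the earlier one, with wider room on either side; only a single pair shows that change. Compound 4 is therefore estimated to give 180000 nM, between 100000 nM and 350000 nM.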

Compound 4, half-maximal inhibitory concentration: 110000 nM
The estimate for compound 4 lay 1.6-fold (0.21 log units) above the measured number; low and high end bracket the measured number.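

In this assay, chloro in place of methyl on the aromatic carbon of the second core gave a 1.4-fold lower number from compound 3 to compound 4 (0.13 log units; within the scatter). Set beside the earlier pair, this step does not differ from it: the same change on two cores in this assay, a 1.3-fold higher number (0.12 log units; within the scatter) from compound 1 to compound 2 and a 1.4-fold lower number (0.13 log units; within the scatter) from compound 3 to compound 4, 1.8-fold (0.26 log units) apart, within the scatter of two such steps. On these two cores, then, the change carries over as a step within the scatter, but two pairs cannot show that it would stay so on other cores, and steps this small cannot reveal a slight real effect of the change.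

The compounds shown leave open what a methoxy group, a nitrile or an amine would do at the same place on the ring. They also leave open how a carboxylic acid in place of an ethyl ester would read.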